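A few compounds are considered here, and "the series" means these few. Any claim that something is new, unique, unknown or untested is made for them only; others in the source may bear on it.

In a functional assay on MCF7 cells (Homo sapiens) for antiproliferative activity, read by MTT assay, with a stated time of 48 h (on this read-out higher numbers stand for weaker inhibition and lower numbers for stronger inhibition), compound 1 `COc1ccc(C(=O)c2ccc(OC)c3c2C=CC(C)(C)O3)c(NC(=O)CO)c1` gives 940 nM as its value. Compound 2 `COc1ccc(C(=O)c2ccc(OC)c3c2OC(C)(C)C=C3)c(NC(=O)CN)c1` gives 410 nM and compound 3 `C=C(c1ccc2c(c1)C=CC(C)(C)O2)c1ccc(OC)cc1NC(=O)CO` gives 390 nM on the same read-out. Compound 3 therefore inhibits more strongly than compound 1, beyond the scatter, but cannot be told apart from compound 2. Compound 4 `C=C(c1ccc2c(c1)C=CC(C)(C)O2)c1ccc(OC)cc1NC(=O)CNCC` differs from compound 3 in one place (ethylamino in place of hydroxy on a saturated chain carbon bound to a carbonyl carbon), with ethylamino in place of hydroxy on a saturated chain carbon bound to a carbonyl carbon. For the measured compounds named here, no measured pair shows this exact swap. Compound 2, whose side chain also carries nitrogen, gives 410 nM and sits close to compound 3, so no step beyond the scatter is expected. The estimated step is small (a 1.1-fold lower number from compound 3 to compound 4 (0.05 log units; within the scatter)). For compound 4 the estimated value is 350 nM with an expected range from 120 nM to 1000 nM in this measurement.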

Compound 4, half-maximal inhibitory concentration: 3370 nM
Estimate against measurement, compound 4: 9.6-fold (0.98 log units) below; measured number above the stated range.
By their numbers in this assay, from the lowest: compounds 3 and 2 (each within the scatter of the next); then compound 1; then compound 4.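

The swap of hydroxy for ethylamino on this saturated chain carbon bound to a carbonyl carbon is not a neutral one: in this assay it gives an 8.6-fold higher number from compound 3 to compound 4 (0.94 log units; beyond the scatter). Both groups count one hydrogen-bond donor and one hydrogen-bond acceptor, so these counts alone do not predict the result at this position. Nothing measured here gives a cause for the step. The compounds shown leave open whether the nitrogen or the two added carbons matter more. A methylamino or dimethylamino group on the same carbon of the core of compound 3 would help separate the two.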